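The compounds below may be only part of what the source reports. "The series", "measured", "known", "first", "only" and "open" are said of these compounds alone.

Compound 1 `C[C@@H](CO)Nc1nc(C(=O)NCc2ccc(F)cc2)c(O)c2ncccc12` has no number of its own in a functional assay on MCF7 cells (Homo sapiens) for cytotoxicity, read by MTT assay, with a stated time of 72 h; on this read-out higher numbers stand for weaker inhibition and lower numbers for stronger inhibition: for compound 1 the record reads "not determined" (no result reported). Compound 2 `N[C@H]1CC[C@H](Nc2c(C(=O)NCc3ccc(Cl)cc3)nc(Br)c3cccnc23)CC1` stands in the same position, since in this assay compound 2 gives "not determined" (no result reported). Going by the values given here, the only measured value in this set comes from compound 3 `NCCCNc1c(C(=O)NCc2ccc(F)cc2)nc(Br)c2cccnc12`, which in this assay gives 6000 nM. Compound 4 `O=CNCCCCCCNc1nc(C(=O)NCc2ccc(F)cc2)c(O)c2ncccc12` has not yet been measured. Compound 4 differs from compound 1 in one place: 6-(formylamino)hexyl in place of 1-(hydroxymethyl)ethyl on a nitrogen on an aromatic ring. Among the compounds with values here, no measured pair shows this kind of change, so no step can be computed, and the size and direction of the effect in this assay cannot be read from the data; with no number for compound 1, the expectation for compound 4 cannot be anchored to its direct parent and rests on compound 3 alone, a close relative of the same shared core. Compound 4 is expected to give about 5000 nM, within a range from 1500 nM to 20000 nM, because compound 3 gives 6000 nM.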

Compound 4, half-maximal inhibitory concentration: 19000 nM
Estimate against measurement, compound 4: 3.8-fold (0.58 log units) below; measured number inside the range.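

No new step can be read for compound 4: compound 1, which alone differs from it in one place, has no number to set against it. No evidence on hand bears on this result. The compounds shown leave open what replacing 1-(hydroxymethyl)ethyl with 6-(formylamino)hexyl does to cytotoxicity.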